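From Bromophenyl Ester to a Carboxy Side Chain

The compounds below may be only part of what the source reports. "The series", "measured", "known", "first", "only" and "open" are said of these compounds alone.

In a functional assay on DU-145 cells (Homo sapiens) for cytotoxicity, read by trypan blue exclusion, with a stated time of 96 h (on this read-out higher numbers stand for weaker inhibition and lower numbers for stronger inhibition), compound 1 (`COC(=O)C(Nc1cc(NS(=O)(=O)/C=C/c2c(OC)cc(OC)cc2OC)ccc1OC)c1ccccc1`) gives 2500 nM, and compound 2 (`COC(=O)C(Nc1cc(NS(=O)(=O)/C=C/c2c(OC)cc(OC)cc2OC)ccc1OC)c1ccc(F)cc1`) gives 2500 nM, with no change at the digits printed from compound 1 to compound 2 (within the scatter). Compound 3 (`COC(=O)C(Nc1cc(NS(=O)(=O)/C=C/c2c(OC)cc(OC)cc2OC)ccc1OC)c1ccc(Br)cc1`) gives 7500 nM, the highest number of the three and so the weakest inhibition in the set. It is separated from the other two by a 3.0-fold higher number from compound 1 to compound 3 (0.48 log units; beyond the scatter) and a 3.0-fold higher number from compound 2 to compound 3 (0.48 log units; beyond the scatter).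

Compound 4 (`COc1cc(OC)c(/C=C/S(=O)(=O)Nc2ccc(OC)c(NC(C)(C)C(=O)O)c2)c(OC)c1`) has a far larger change: 1-carboxy-1-methylethyl in place of (4-bromophenyl)(methoxycarbonyl)methyl on a nitrogen on an aromatic ring. The whole (4-bromophenyl)(methoxycarbonyl)methyl group gives way to 1-carboxy-1-methylethyl on the nitrogen.

The measured steps bear on this only in part. Each alters a single substituent on the aromatic ring that compound 4 no longer has, and none replaces the ester or the ring itself. The bromo also leaves, and its arrival came with a 3.0-fold higher number from compound 1 to compound 3 (0.48 log units; beyond the scatter), so a lower number than that of compound 3 is expected, back towards compound 1 at 2500 nM. Nothing measured shows what the carboxy group does, so the uncertainty is wide. The expected change is a 9.4-fold lower number from compound 3 to compound 4 (0.97 log units; beyond the scatter), towards stronger inhibition. For compound 4, the estimated value is 800 nM, with an expected range from 60 nM to 10000 nM.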

Compound 4, half-maximal inhibitory concentration: 70 nM
Estimate against measurement, compound 4: 11-fold (1.06 log units) above; measured number inside the range.
By their numbers in this assay, from the lowest: compound 4; then compounds 1 and 2 (each within the scatter of the next); then compound 3.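

Replacing the whole group on the nitrogen moves the number much further than any change on the ring of the side chain had: in this assay the exchange gives a 110-fold lower number from compound 3 to compound 4 (2.03 log units; beyond the scatter) and the same kind of replacement gives a 36-fold lower number from compound 2 to compound 4 (1.55 log units; beyond the scatter) and a 36-fold lower number from compound 1 to compound 4 (1.55 log units; beyond the scatter) in the two other cases. The earlier compounds had shown only that this side chain responds modestly to a bromo and not at all to a fluoro, whereas compound 4, the strongest inhibitor of the four, shows that neither the six-membered aromatic ring nor the methoxycarbonyl group is needed here for a low number. Nothing available gives a reason for this gain.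

The step changes several features at once, so the compounds shown do not separate the part played by the free carboxylic acid from that of the two methyl groups or of the lost ring. As far as these compounds go, it stays open whether a carboxymethyl group without those methyl groups, the methyl ester of the 1-carboxy-1-methylethyl group, or a carboxylic acid with the phenyl ring retained would give a number like that of compound 4.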